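This account rests on a few compounds, and the source may have more. Where it says the series, first, only, none or still open, it means among the compounds named here.

Compound 2 `Cc1cc(C)c(S(=O)(=O)N2CCC(N3CCC(O)CC3)CC2)c(C)c1` is the starting point. In a functional assay on DLD-1 cells (Homo sapiens) for antiproliferative activity, read by CellTiter-Glo, with a stated time of 72 h (a lower number here means a stronger inhibitor, a higher number a weaker inhibitor), compound 2 gives 106 nM. Compound 3 `Cc1cc(C)c(S(=O)(=O)N2CCC(N3CCN(C)CC3)CC2)c(C)c1` gives 1100 nM in this assay. Compound 1 `Cc1cc(C)c(S(=O)(=O)N2CCC(C3OCC(C)CO3)CC2)c(C)c1` reaches only a limit of this assay, namely > 5000 nM. That limit is the one described as the limit of > 5000 nM in this assay, at which 1 of the 3 values shown sits. Compound 2 therefore holds the lowest of the two real numbers, and the nearest, compound 3, lies a large step away: a 10-fold higher number from compound 2 to compound 3 (1.02 log units; beyond the scatter). The change an at least 47-fold lower number from compound 1 to compound 2 (1.67 log units; beyond the scatter) is larger still, and the change an at least 4.5-fold lower number from compound 1 to compound 3 (0.65 log units; beyond the scatter) is at least modest.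

Compound 4 `Cc1cc(C)c(S(=O)(=O)N2CCC(N3CCC(c4ccccc4)CC3)CC2)c(C)c1` differs from compound 2 in one place: phenyl in place of hydroxy on a saturated ring carbon. Among the compounds with values here, no measured step exchanges a hydroxy for a phenyl, so the bearing of the known steps is indirect. The step from compound 2 to compound 3 shows that a change at the far end of this ring can move the number by a large step, while the ring nitrogen that compound 2 and compound 3 share is kept in compound 4. The expected step here is a 3.3-fold higher number from compound 2 to compound 4 (0.52 log units; beyond the scatter), a rise of modest size with wide uncertainty. Compound 4 is expected to give 350 nM, between 60 nM and 3000 nM.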

Compound 4, half-maximal inhibitory concentration: 865 nM
Beside the measured number, compound 4's estimate is 2.5-fold (0.39 log units) below it; measured number inside the range.
By their numbers in this assay, from the lowest: compound 2; then compounds 4 and 3 (each within the scatter of the next). At a limit, above all of these: compound 1.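

At this saturated ring carbon, three ring bonds from the ring nitrogen, phenyl in place of hydroxy gives an 8.2-fold higher number from compound 2 to compound 4 (0.91 log units; beyond the scatter) in this assay, a modest loss. Unlike the earlier step to compound 3, which exchanged the whole ring, this change leaves the ring and its nitrogen in place, so it shows that the group on this carbon alone can move the number beyond the scatter. The data shown give no measured basis for explaining this rise.

Still open, as far as these compounds go, is whether an amine, a methoxy group or a carboxylic acid on this same carbon would keep the number near that of compound 2, which gives 106 nM. Also open, from the compounds shown here alone, is whether a longer chain such as hydroxymethyl or a benzyl group would behave like hydroxy or like phenyl here.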